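This account rests on a few compounds, and the source may have more. Where it says the series, first, only, none or still open, it means among the compounds named here.

Compound 1 `Cc1ccccc1N(C)C(=O)c1ccc(-c2ccc(OS(N)(=O)=O)cc2F)o1`: 12 nM
Compound 2 `Cc1cccc(F)c1N(C)C(=O)c1ccc(-c2ccc(OS(N)(=O)=O)cc2)o1`: 150 nM
Compound 3 `Cc1ccc(F)cc1N(C)C(=O)c1ccc(-c2ccc(OS(N)(=O)=O)cc2)o1`: 40 nM

All three were tested in an assay on T47D cells for inhibition of Steryl-sulfatase (Homo sapiens), read by HPLC, with a stated time of 24 h; a lower number here means a stronger inhibitor, a higher number a weaker inhibitor. Among these three numbers compound 3 stands second highest: compound 1 sits at a lower number and compound 2 at a higher one, and both gaps lie beyond the scatter of repeated measurements. Compound 4 `Cc1c(F)cccc1N(C)C(=O)c1ccc(-c2ccc(OS(N)(=O)=O)cc2)o1` has not yet been measured. It differs from compound 3 only in where the fluorine sits on the ring carried by the amide nitrogen: 3-fluoro-2-methylphenyl in place of 5-fluoro-2-methylphenyl on an amide-type nitrogen. The two share the same atoms, joined differently.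

Among the compounds with values here, only one measured step bears on a change of this kind. a 3.8-fold lower number from compound 2 to compound 3 (0.57 log units; beyond the scatter) shows that shifting the fluorine to a different spot on that same ring, with the methyl kept, produced a modest change beyond the scatter. Within the data shown here, no measured pair covers the exact fluorine placement of compound 4, so the direction of its step is uncertain, and a shift of similar or smaller size is expected in this assay, leaning slightly toward a higher number. The expected step is a 1.5-fold higher number from compound 3 to compound 4 (0.18 log units; within the scatter). Compound 4 is estimated to give about 60 nM, with a likely range from 20 nM to 200 nM.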

Compound 4, half-maximal inhibitory concentration: 27 nM
The estimate for compound 4 lay 2.2-fold (0.35 log units) above the measured number; the measured number falls inside the stated range.
By their numbers in this assay, from the lowest: compound 1; then compounds 4 and 3 (each within the scatter of the next); then compound 2.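

In this assay, moving the fluorine from the 5-fluoro-2-methylphenyl arrangement to the 3-fluoro-2-methylphenyl arrangement gives a 1.5-fold lower number from compound 3 to compound 4 (0.17 log units; within the scatter), so these two placements on the ring carried by the amide-type nitrogen cannot be told apart in this test. The 2-fluoro-6-methylphenyl group of the earlier series now stands apart from both of them: a 5.6-fold lower number from compound 2 to compound 4 (0.74 log units; beyond the scatter) joins a 3.8-fold lower number from compound 2 to compound 3 (0.57 log units; beyond the scatter), and each of these steps lies beyond the usual scatter, so among the three arrangements shown, only this one separates from the others. No measurement is available that would explain this difference.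

The compounds shown leave open whether this ring would respond in the same way if a chlorine atom or a methoxy group stood in place of the fluorine. They also leave open what an ethyl group in place of the methyl would do, and whether the close agreement between the 3-fluoro-2-methylphenyl and 5-fluoro-2-methylphenyl groups would hold for such larger replacements.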